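This account rests on a few compounds, and the source may have more. Where it says the series, first, only, none or still open, it means among the compounds named here.

Measured in a functional assay on HT-29 cells (Homo sapiens) for antiproliferative activity, read by MTT assay, with a stated time of 72 h; on this read-out higher numbers stand for weaker inhibition and lower numbers for stronger inhibition:
Compound 1 `CCN1CCN(CCCOc2cc3nccc(Oc4c(F)cc(NC(=O)NN5C(=O)CSC5c5c(F)cccc5F)cc4F)c3cc2OC)CC1` gives 73 nM.
Compound 2 `COc1cc2c(Oc3c(F)cc(NC(=O)NN4C(=O)CSC4c4c(F)cccc4F)cc3F)ccnc2cc1OCCCN1CCc2sccc2C1` gives 1410 nM.
Compound 3 `COc1cc2c(Oc3c(F)cc(NC(=O)NN4C(=O)CSC4c4c(F)cccc4F)cc3F)ccnc2cc1OCCCN1CCN(C)CC1` gives 150 nM.

Compound 3 stands second highest of the three numbers in this assay. Compound 1 is nearest to it, with a 2.1-fold higher number from compound 1 to compound 3 (0.31 log units; beyond the scatter), and compound 2 is furthest, with a 9.4-fold lower number from compound 2 to compound 3 (0.97 log units; beyond the scatter).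

Compound 4 `CCN(CC)CCCOc1cc2nccc(Oc3c(F)cc(NC(=O)NN4C(=O)CSC4c4c(F)cccc4F)cc3F)c2cc1OC` differs from compound 3 only at the end of the chain: diethylamino in place of 4-methylpiperazin-1-yl on a saturated chain carbon, three bonds along the chain from an oxygen on an aromatic ring. Among the compounds with values here, no measured pair shows this exact exchange. Within the data shown here, the steps that bear on it all sit at the same place on the chain: a 19-fold higher number from compound 1 to compound 2 (1.29 log units; beyond the scatter) is large, a 9.4-fold lower number from compound 2 to compound 3 (0.97 log units; beyond the scatter) is modest, and a 2.1-fold higher number from compound 1 to compound 3 (0.31 log units; beyond the scatter) is only just beyond the scatter. The terminal amine therefore clearly moves the numbers in this assay, but the measured groups give no direct pointer for an acyclic amine that carries no ring. A step of modest size is expected, most likely toward a somewhat higher number, though a result within the scatter of compound 3 cannot be excluded. For compound 4 the expected step in this assay is a 1.5-fold higher number from compound 3 to compound 4 (0.17 log units; within the scatter). Compound 4 is thus estimated at 220 nM, in the range 70 nM to 700 nM.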

Compound 4, half-maximal inhibitory concentration: 91 nM
The estimate for compound 4 lay 2.4-fold (0.38 log units) above the measured number; low and high end bracket the measured number.
By their numbers in this assay, from the lowest: compounds 1, 4 and 3 (each within the scatter of the next, the first and the last beyond it); then compound 2.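

In this assay, the terminal amine on the saturated chain does not need a ring to give numbers in the range of the piperazines: diethylamino in compound 4 stays within the scatter of 4-methylpiperazin-1-yl (a 1.6-fold lower number from compound 3 to compound 4 (0.22 log units; within the scatter)) and of 4-ethylpiperazin-1-yl (a 1.2-fold higher number from compound 1 to compound 4 (0.10 log units; within the scatter)). The second nitrogen and the ring of the piperazines are therefore not required at this place, at least among these compounds, and compound 2 remains the outlier, now also against an acyclic amine (a 15-fold lower number from compound 2 to compound 4 (1.19 log units; beyond the scatter)). No measurement at hand accounts for these steps.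

Still open, going by these compounds, is whether a morpholine, an unsubstituted piperazine or a dimethylamino group at the chain end would also stay within the scatter of compounds 1, 3 and 4, and whether a 2-(diethylamino)ethyl chain or a longer chain would do the same. Also open, on these data alone, is whether the high number of compound 2 goes with its five-membered aromatic ring, since a piperidine at the chain end would separate that ring from the amine.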